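The source may report more compounds than this note shows. Statements on the series, on what has been measured and on what is new or still open speak of the compounds shown alone.

Going by the values given here, in an assay on cell membranes for inhibition of adenosine receptor A1 (Rattus norvegicus) (a lower number here means a stronger inhibitor, a higher number a weaker inhibitor), compound 2 `O=C(O)CC1=C(n2nc(-c3c(-c4ccccc4)nn4ccccc34)ccc2=O)CCC1` gives 11 nM, the lowest of the two numbers recorded so far, though its only neighbour sits within the scatter: in this assay compound 1 `O=C(O)CC1=C(n2nc(-c3c(-c4ccccc4)nn4ccccc34)ccc2=O)CCCC1` gives 15 nM, and a 1.4-fold lower number from compound 1 to compound 2 (0.13 log units; within the scatter). Compound 3 `O=C(O)CC1=C(n2nc(-c3c(-c4ccccc4)nn4ccccc34)ccc2=O)CCCCC1` has not yet been measured in this assay. It differs from compound 2 in a single place: 2-(carboxymethyl)cyclohept-1-en-1-yl in place of 2-(carboxymethyl)cyclopent-1-en-1-yl on an aromatic nitrogen. Among the compounds with values here, the one measured step that bears on this change is the earlier swap of ring size on the same aromatic nitrogen, from the cyclohexenyl ring to the cyclopentenyl ring, where a 1.4-fold lower number from compound 1 to compound 2 (0.13 log units; within the scatter) did not move the number beyond the scatter. Going the other way, to a seven-membered ring, is a wider change in ring size than the one already seen, so there is no ground for expecting a shift beyond the scatter, but the uncertainty is somewhat greater. The number for compound 3 in this assay is therefore expected to stay close to that of compound 2, a 1.3-fold higher number from compound 2 to compound 3 (0.10 log units; within the scatter). Compound 3 is estimated at 14 nM, with a range from 6 nM to 35 nM.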

Compound 3, half-maximal inhibitory concentration: 16 nM
The estimate for compound 3 lay 1.1-fold (0.06 log units) below the measured number; the measured number falls inside the stated range.
By their numbers in this assay, from the lowest: compounds 2, 1 and 3 (each within the scatter of the next).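

Adding the seven-membered ring extends the comparison in this assay beyond the earlier pair: there is a 1.5-fold higher number from compound 2 to compound 3 (0.16 log units; within the scatter) and also a 1.1-fold higher number from compound 1 to compound 3 (0.03 log units; within the scatter) for this change. With 2-(carboxymethyl)cyclopent-1-en-1-yl, 2-(carboxymethyl)cyclohex-1-en-1-yl and 2-(carboxymethyl)cyclohept-1-en-1-yl on the same aromatic nitrogen, all three compounds now lie within the scatter of one another, so this assay does not separate these three ring sizes at this position. Nothing available here accounts for that flat result.

On these data alone, all three compounds keep the same carboxymethyl group on a ring with one double bond, so it remains open how the number would respond if the carboxylic acid gave way to a methyl ester or a primary amide, or if the acid sat on a longer chain such as carboxyethyl. As far as these compounds go, it is also open whether an eight-membered carbon ring, a saturated ring, or an open chain in place of the ring would stay within the same narrow band, and these three compounds give no way of judging any of those changes.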